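Replacing the hydroxynitrophenyl ring in a weak growth inhibitor

The compounds below may be only part of what the source reports. "The series", "measured", "known", "first", "only" and "open" are said of these compounds alone.

Measured compounds:
- compound 1 `Cc1ccc(S(=O)(=O)/C(=C/c2ccc(O)c([N+](=O)[O-])c2)C(=O)c2ccc(Cl)cc2)cc1`: 25000 nM
- compound 2 `O=C(/C(=C\c1ccc(O)c([N+](=O)[O-])c1)SCc1ccccc1Cl)c1ccc(Cl)cc1`: 10000 nM

In a functional assay on DU-145 cells (Homo sapiens) for inhibition, read by trypan blue exclusion, with a stated time of 96 h (on this read-out lower numbers stand for stronger inhibition of growth and higher numbers for weaker inhibition of growth), compound 1 gives 25000 nM, the highest of the two numbers shown; its nearest neighbour is compound 2, and the only measured step, a 2.5-fold lower number from compound 1 to compound 2 (0.40 log units; beyond the scatter), lies at a different place, where (2-chlorobenzyl)sulfanyl replaces (4-methylphenyl)sulfonyl on a double-bonded chain carbon bound to a carbonyl carbon and a double-bonded chain carbon.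

Compound 3 `Cc1ccc(S(=O)(=O)/C(=C/c2cc(C)ccc2C)C(=O)c2ccc(Cl)cc2)cc1` has not been measured. It differs from compound 1 as follows: 2,5-dimethylphenyl in place of 4-hydroxy-3-nitrophenyl on a double-bonded chain carbon bound to a double-bonded chain carbon. No measured step touches this part of the shared core, so the step from compound 1 to compound 2 offers no guide to it, and nothing shown tells how the loss of the hydrogen-bond donor and the acceptors will read out in this assay. With compound 1 already among the weaker numbers, the expected change is small and of uncertain direction: the estimated step is a 1.2-fold higher number from compound 1 to compound 3 (0.08 log units; within the scatter). Compound 3 is therefore estimated at 30000 nM, with a range from 8000 nM to 100000 nM.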

Compound 3, concentration for 50% growth inhibition: 1000 nM
Compound 3: the middle estimate sits 30-fold (1.48 log units) above what was measured; the measured number lies below the stated range.
By their numbers in this assay, from the lowest: compound 3; then compound 2; then compound 1.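

In this assay, the step to 2,5-dimethylphenyl in place of 4-hydroxy-3-nitrophenyl, a 25-fold lower number from compound 1 to compound 3 (1.40 log units; beyond the scatter), shows that the group on this double-bonded chain carbon can move the number strongly, which the earlier pair could not show, as it differs only where (2-chlorobenzyl)sulfanyl replaces (4-methylphenyl)sulfonyl. It also shows that, on the core of compound 1, neither the hydrogen-bond donor nor the hydrogen-bond acceptors of 4-hydroxy-3-nitrophenyl are needed for growth inhibition, as the 2,5-dimethylphenyl of compound 3 carries none of them and still gives the lower number. No measurement shown explains this gain or ties it to any property of either group.

The compounds shown leave open whether the gain comes from losing the hydroxy and nitro groups or from gaining the two methyl groups, and whether a single methyl, a methoxy group or a chlorine on this ring would read the same. They also leave open whether 2,5-dimethylphenyl would give a similar step on a compound carrying the (2-chlorobenzyl)sulfanyl group of compound 2.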